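Swapping the halogen-bearing phenyl on compound 1

This account rests on a few compounds, and the source may have more. Where it says the series, first, only, none or still open, it means among the compounds named here.

Three compounds share one core and differ only in the aromatic ring attached to an aromatic nitrogen of that core. In a functional assay on PC-3 cells (Homo sapiens) for cytotoxicity, read by MTT assay, with a stated time of 72 h (a higher number here means a weaker inhibitor, a lower number a stronger inhibitor), compound 1 `O=C(Nc1ccc(Oc2ccnc3[nH]ccc23)cc1)c1nn(-c2ccc(Br)cc2)ccc1=O` gives 8040 nM. Compound 2 `O=C(Nc1ccc(Oc2ccnc3[nH]ccc23)cc1)c1nn(-c2ccccc2)ccc1=O`, which carries a plain phenyl, gives 15000 nM in this assay, and compound 3 `O=C(Nc1ccc(Oc2ccnc3[nH]ccc23)cc1)c1nn(-c2ccc(Br)cc2F)ccc1=O`, with a 4-bromo-2-fluorophenyl, gives 12800 nM. Neither number is separated from that of compound 1 beyond the scatter: the step of a 1.9-fold higher number from compound 1 to compound 2 (0.27 log units; within the scatter) and the step of a 1.6-fold higher number from compound 1 to compound 3 (0.20 log units; within the scatter) are both small, and so is a 1.2-fold lower number from compound 2 to compound 3 (0.07 log units; within the scatter).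

Compound 4 `O=C(Nc1ccc(Oc2ccnc3[nH]ccc23)cc1)c1nn(-c2ccc(Cl)c(F)c2)ccc1=O` has not yet been measured. It differs from compound 1 by 4-chloro-3-fluorophenyl in place of 4-bromophenyl on an aromatic nitrogen. The two steps that bear on this change, a 1.9-fold higher number from compound 1 to compound 2 (0.27 log units; within the scatter) and a 1.6-fold higher number from compound 1 to compound 3 (0.20 log units; within the scatter), show that removing the bromo or adding a fluoro to the ring on this nitrogen moved the number only within the scatter. A change that exchanges one halogen for another and adds a fluoro is therefore expected to give no step beyond the scatter, with at most a slight drift toward a higher number.

For compound 4 the estimate in this assay is 10000 nM, between 4000 nM and 25000 nM. The step from compound 1 is expected to be a 1.2-fold higher number from compound 1 to compound 4 (0.09 log units; within the scatter).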

Compound 4, half-maximal inhibitory concentration: 7780 nM
For compound 4 the middle estimate is 1.3-fold (0.11 log units) above the measured one; the range from low to high includes it.
By their numbers in this assay, from the lowest: compounds 4, 1, 3 and 2 (each within the scatter of the next).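

In this assay, exchanging the 4-bromophenyl for 4-chloro-3-fluorophenyl leaves the number essentially unchanged (a 1.0-fold lower number from compound 1 to compound 4 (0.01 log units; within the scatter)), so in this set the bromo is not required on the ring at this nitrogen. Compound 4 also stays close to the other two compounds, with (a 1.6-fold lower number from compound 3 to compound 4 (0.22 log units; within the scatter)) and (a 1.9-fold lower number from compound 2 to compound 4 (0.29 log units; within the scatter)) both small steps. Compound 4 thus extends what the earlier compounds suggested: plain phenyl and rings with different halogens, in different places, all give numbers within the scatter of one another, and no compound shown goes against this.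

From the compounds shown here alone, all four compounds carry a phenyl ring on this nitrogen, so it remains open whether the numbers would move with an amine or a carboxylic acid on that ring, or with a longer alkyl chain in place of the ring. Nothing available here explains why these ring changes leave the number in this narrow band.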